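Chalcone Aryl Swap: From Methylsulfanyl to Methoxy

A few compounds are considered here, and "the series" means these few. Any claim that something is new, unique, unknown or untested is made for them only; others in the source may bear on it.

Measured so far:
Compound 1, `COc1cc(O)c(C(=O)/C=C/c2ccc(F)cc2)c(OC)c1`, gives 59% in a functional assay on HCT-116 cells (Homo sapiens), read by fluorescence and BrdU incorporation, with a stated time of 48 h, tested at 10 uM; on this read-out higher numbers stand for a weaker effect at the one concentration tested and lower numbers for a stronger effect.
Compound 2, `COc1cc(OC)c(C(=O)/C=C/c2ccccc2SC)c(OC)c1`, gives 25% in this assay.

Of the two numbers in hand, compound 2 stands lowest, and the gap to compound 1 lies beyond the usual scatter, so compound 2 shows the stronger effect of the pair in this assay. Going by the values given here, no step between measured compounds that differ in one place is available, so no measured step size can guide the next move.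

Compound 3, `COc1cccc(/C=C/C(=O)c2c(OC)cc(OC)cc2OC)c1`, differs from compound 2 in one place: 3-methoxyphenyl in place of 2-(methylsulfanyl)phenyl on a double-bonded chain carbon bound to a double-bonded chain carbon. Among the compounds with values here, with no comparable step recorded, the size of this change in this assay is open; a moderate loss of effect is expected, yet the outcome could also stay within the scatter of compound 2. Compound 3 is expected to give 40%, within 15% to 70%, which would mean an estimated step of a number 15 percentage points higher from compound 2 to compound 3 (beyond the scatter).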

Compound 3, a percentage reported as activity, at one concentration (the size of the read-out at that concentration, not a potency): 20%
Beside the measured number, compound 3's estimate is 20 percentage points above it; low and high end bracket the measured number.
By their numbers in this assay, from the lowest: compounds 3 and 2 (each within the scatter of the next); then compound 1.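

In this assay, going by these compounds alone, 3-methoxyphenyl in place of 2-(methylsulfanyl)phenyl on a double-bonded chain carbon bound to a double-bonded chain carbon gives a number 5 percentage points lower from compound 2 to compound 3 (within the scatter), the first step between compounds that differ in one place. At this position, then, the two groups cannot be told apart on this read-out, and the sulfur of compound 2 is not needed to retain the effect seen there. No measured evidence bears on why the two groups give such similar results.

This single step changes both the atom and the place named in the group, so the compounds shown do not separate these two changes. They also leave open whether an amine or a carboxylic acid on this aromatic ring would keep the effect of compound 2 and compound 3.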